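The compounds below may be only part of what the source reports. "The series", "measured", "known", "first", "only" and "open" are said of these compounds alone.

Values in a physicochemical assay, with a stated time of 30 min; a lower number here means a stronger inhibitor, a higher number a weaker inhibitor:
- compound 1 `COc1ccc(NC(=O)C2Cc3cc(OC)c(OC)cc3C2=O)cc1`: 49.5 ug/mL
- compound 2 `COc1cc2c(cc1OC)C(=O)C(C(=O)Nc1cccc(Cl)c1)C2`: 76.3 ug/mL
- compound 3 `COc1cc2c(cc1OC)C(=O)C(C(=O)Nc1cccc(Br)c1)C2`: 58.9 ug/mL

Compound 3, at 58.9 ug/mL, lies within the scatter of both other compounds. Compound 4 `COc1cc2c(cc1OC)C(=O)C(C(=O)Nc1ccccc1F)C2` differs from it by 2-fluorophenyl in place of 3-bromophenyl on an amide-type nitrogen. The bearing steps are the other exchanges on that nitrogen: a 1.5-fold higher number from compound 1 to compound 2 (0.19 log units; within the scatter), a 1.2-fold higher number from compound 1 to compound 3 (0.08 log units; within the scatter) and a 1.3-fold lower number from compound 2 to compound 3 (0.11 log units; within the scatter). All three stay within the scatter, though none involves 2-fluorophenyl, so the support is indirect. No step beyond the scatter is therefore expected in this assay. The expected step is a 1.0-fold higher number from compound 3 to compound 4 (0.01 log units; within the scatter). Compound 4 is estimated at 60 ug/mL, with an expected range of 30 ug/mL to 115 ug/mL.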

Compound 4, half-maximal inhibitory concentration: 75.7 ug/mL
Compound 4: middle estimate off by 1.3-fold (0.10 log units), on the low side; the range from low to high includes it.
By their numbers in this assay, from the lowest: compounds 1, 3, 4 and 2 (each within the scatter of the next).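

In this assay the 2-fluorophenyl amide stays inside the scatter of every other compound, with a 1.3-fold higher number from compound 3 to compound 4 (0.11 log units; within the scatter) and a 1.0-fold lower number from compound 2 to compound 4 (0.00 log units; within the scatter) and also a 1.5-fold higher number from compound 1 to compound 4 (0.18 log units; within the scatter) in this series. The 4-methoxyphenyl, 3-chlorophenyl, 3-bromophenyl and 2-fluorophenyl groups on this nitrogen therefore cannot be told apart in this read-out, and this now includes a direct reading for 2-fluorophenyl. No measurement at hand bears on this result.

Still open, from the compounds shown here alone, is whether a carboxylic acid or an amine on the phenyl ring would give a step beyond the scatter in this assay at this nitrogen. Going by these compounds, the effect of any change on the shared core also remains open.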